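A few compounds are considered here, and "the series" means these few. Any claim that something is new, unique, unknown or untested is made for them only; others in the source may bear on it.

The three measured compounds share one core and differ only in the group sitting on a carbon with a double bond to nitrogen. Compound 1 `CN(C)CCn1cnnc1-c1cc(Oc2ccc(NC(=O)N/N=C/c3cccc(O)c3)cc2F)ccn1` carries a 3-hydroxyphenyl there. In a functional assay on U-87MG ATCC cells (Homo sapiens) for cytotoxicity, read by MTT assay, with a stated time of 72 h (on this read-out higher numbers stand for weaker inhibition and lower numbers for stronger inhibition), compound 1 gives > 100000 nM, which is a limit of the assay and not a number. Compound 1 therefore stands at the weak end of what has been measured, sitting at the limit of > 100000 nM in this assay, at which 1 of the 3 values shown sits. Compound 2 `CN(C)CCn1cnnc1-c1cc(Oc2ccc(NC(=O)N/N=C/c3cccc(Cl)c3Cl)cc2F)ccn1` gives 13200 nM in this assay, and the swap to a 2,3-dichlorophenyl gives an at least 7.5-fold lower number from compound 1 to compound 2 (0.87 log units; beyond the scatter). Compound 3 `CN(C)CCn1cnnc1-c1cc(Oc2ccc(NC(=O)N/N=C/c3c(O)ccc4ccccc34)cc2F)ccn1` gives 620 nM in this assay; the swap to a 2-hydroxynaphthalen-1-yl gives an at least 160-fold lower number from compound 1 to compound 3 (2.20 log units; beyond the scatter), and from compound 2 the step is a 21-fold lower number from compound 2 to compound 3 (1.33 log units; beyond the scatter).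

Compound 4 `CN(C)CCn1cnnc1-c1cc(Oc2ccc(NC(=O)N/N=C/c3ccc(F)cc3F)cc2F)ccn1` has not yet been measured. Its change from compound 1 is 2,4-difluorophenyl in place of 3-hydroxyphenyl on a carbon with a double bond to nitrogen. The step that bears most on it is the one in which the 3-hydroxyphenyl of compound 1 was likewise replaced by a phenyl carrying two halogens, the 2,3-dichlorophenyl, which gave an at least 7.5-fold lower number from compound 1 to compound 2 (0.87 log units; beyond the scatter). A drop of similar, at least modest size is therefore expected in this assay, so the estimated step is an at least 4.0-fold lower number from compound 1 to compound 4 (0.60 log units; beyond the scatter). Compound 4 is estimated at 25000 nM, within a range from 6000 nM to 100000 nM.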

Compound 4, half-maximal inhibitory concentration: 1900 nM
For compound 4 the middle estimate is 13-fold (1.12 log units) above the measured one; measured number below the stated range.
By their numbers in this assay, from the lowest: compound 3; then compound 4; then compound 2. At a limit, above all of these: compound 1.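

In this assay, the swap to the 2,4-difluorophenyl gives an at least 52-fold lower number from compound 1 to compound 4 (1.72 log units; beyond the scatter), a step that starts from a limit of the assay and not from a number. The two phenyl groups that carry two halogens are not interchangeable at this place, as the comparison between them gives a 6.9-fold lower number from compound 2 to compound 4 (0.84 log units; beyond the scatter). The 2,4-difluorophenyl has no hydrogen-bond donor and still comes close to the 2-hydroxynaphthalen-1-yl, although a gap beyond the scatter remains, with a 3.1-fold higher number from compound 3 to compound 4 (0.49 log units; beyond the scatter), so among these four compounds a hydroxyl group is neither required for a low number, as compound 4 has none, nor enough for one, as compound 1 carries one.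

Compound 2 and compound 4 differ both in the halogen and in where it sits on the ring, so these compounds cannot tell which of the two matters; a 2,4-dichlorophenyl or a 2,3-difluorophenyl would separate them. From the compounds shown here alone, it also stays open how a phenyl with a single fluorine, or with an amine in place of the hydroxyl of compound 1, would behave at this place.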